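The source may report more compounds than this note shows. Statements on the series, on what has been measured and on what is new or still open speak of the compounds shown alone.

Working notes on the series in an assay on isolated protein (urine) for inhibition of Myeloperoxidase (Homo sapiens), read by spectrophotometry; on this read-out higher numbers stand for weaker inhibition and lower numbers for stronger inhibition. Compound 1 `CCCCn1nc2ccccc2c1OCC` gives 807 nM. Compound 2 `CCCCCCCCn1nc2ccccc2c1OC` is reported in this assay only as a limit, > 10000 nM, so where it stands on the numbers shown is open; the relevant point is the limit of > 10000 nM in this assay, at which 1 of the 2 values shown sits. Compound 3 `CCCCCCCCn1nc2ccccc2c1OCC` has not yet been measured in this assay. It differs from compound 2 by methyl in place of hydrogen on a saturated chain carbon bound to an oxygen on an aromatic ring. Among the measured compounds shown here, no step between two measured compounds covers this change, and the only comparison to hand, compound 1 against compound 2, alters two places at once, so it gives no direction for this one. The step of an at least 1.2-fold lower number from compound 2 to compound 3 (0.09 log units; that floor lies within the scatter) is expected to be small, leaving weak inhibition in place. The estimate for compound 3 is 8000 nM, with a range from 2000 nM to 30000 nM, and a fair chance that this assay again reports only a limit.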

Compound 3, half-maximal inhibitory concentration: > 10000 nM
Compound 3 ended at the assay's limit (the forecaster's own chance of this, stated with the estimate: 55%); middle value at least 1.2-fold (0.09 log units) away from the limit.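

In this assay, like compound 2, compound 3 is reported only as a limit, > 10000 nM. Among the compounds shown here, with the ethoxy group held fixed, butyl in place of hydrogen on a saturated chain carbon, four bonds along the chain from an aromatic nitrogen, gives an at least 12-fold higher number from compound 1 to compound 3 (1.09 log units; beyond the scatter), the first comparison here that alters one place only, so the weak inhibition follows the chain change. The methoxy to ethoxy step cannot be read, because both of its ends are limits: the limit of > 10000 nM in this assay, at which 2 of the 3 values shown sit.

Open, on these data alone, is whether methoxy to ethoxy moves the number when the shorter chain of compound 1 is in place, and how far past the limit compound 2 and compound 3 lie. Also open, as far as these compounds go, is where a propyl chain, or a butyl chain ending in an amine or a carboxylic acid, would fall in this assay.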